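Aryl exchange on the ring nitrogen of compound 2

This account rests on a few compounds, and the source may have more. Where it says the series, first, only, none or still open, it means among the compounds named here.

The series is followed in a functional assay on HEK293 cells for positive allosteric modulation of metabotropic glutamate receptor 5 (Rattus norvegicus), read by fluorescence and calcium flux; on this read-out lower numbers stand for an effect already at smaller amounts and higher numbers for an effect only at larger amounts of compound. Going by the values given here, compound 1 `O=C(COCc1ccccc1)N1CCN(c2ncccc2C(F)(F)F)CC1` is the only member with a number so far and gives 4300 nM in this assay. Compound 2 `O=C(COCc1ccccc1)N1CCN(c2cccnc2)CC1`, which carries pyridin-3-yl on the amine nitrogen in the ring, is reported in this assay as "not active" (no number reported), so there is no single number to place it on; it stands at the inactive end of what has been seen, while compound 1 shows a measurable, weak effect.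

Compound 3 `O=C(COCc1ccccc1)N1CCN(c2ccccc2Cl)CC1` has not been measured. It differs from compound 2 in one place: 2-chlorophenyl in place of pyridin-3-yl on an amine nitrogen in a ring. Among the compounds with values here, no measured step exists for this pair, so only an expectation can be given. Since compound 2 gave no number at all, any response from compound 3 would be a gain rather than a loss; the size of that gain cannot be read from two data points, and it is as likely that compound 3 again yields only a limit as that it gives a value.

Compound 3 is estimated at 6000 nM, with a range of 1500 nM to 25000 nM, in this assay.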

Compound 3, half-maximal effective concentration: 820 nM
Compound 3: middle estimate off by 7.3-fold (0.86 log units), on the high side, and the stated range ends above it.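

Going by these compounds alone, compound 2 has no number in this assay and compound 3 gives 820 nM there, so no step between compound 2 and compound 3 can be read. No further measurement bears on this result. The compounds shown leave open how large the gain from pyridin-3-yl to 2-chlorophenyl is.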